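The source may hold more compounds than are shown below. What is called first, only, known or untested is meant among the compounds shown, and "the series" means these compounds.

Compound 1 `Cc1nc2c(c(-c3cc(F)c4c(c3C)CCCO4)c1[C@H](OC(C)(C)C)C(=O)O)CN(CCCc1ccc(F)cc1)CC2`: in an ADME assay on MT2 cells (Homo sapiens) for cytotoxicity, read by XTT assay, with a stated time of 4 days (a higher number here means that more compound is tolerated, a lower number that less compound is tolerated), compound 1 gives > 40000 nM, which is a limit of the assay and not a number.
Compound 2 `Cc1ccc(-c2c3c(nc(C)c2C(OC(C)(C)C)C(=O)O)CCN(S(C)(=O)=O)C3)cc1`: in this assay compound 2 gives > 40000 nM, also a limit.
Compound 3 `Cc1nc2c(c(-c3cc(F)c4c(c3C)CCCO4)c1[C@H](OC(C)(C)C)C(=O)O)CN(CC1CC1c1ccccc1)CC2`: in this assay compound 3 gives > 40000 nM, again a limit.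

Compound 2 therefore stands where every measured compound in this set stands: at the limit, with no number of its own. (the limit of > 40000 nM in this assay, at which 3 of the 3 values shown sit). Among the measured compounds shown here, the one step between measured compounds, a step that the two limits leave unreadable from compound 1 to compound 3, is not readable either, since both of its ends sit at that same limit; it exchanges a group on a saturated chain carbon bound to an amine nitrogen in a ring.

The new compound 4 `COC(=O)N1CCc2nc(C)c(C(OC(C)(C)C)C(=O)O)c(-c3ccc(C)cc3)c2C1` differs from compound 2 by methoxycarbonyl in place of methylsulfonyl on an amine nitrogen in a ring. This change sits on the amine nitrogen in a ring itself, whereas the measured step changed a group on a carbon bound to such a nitrogen. For the measured compounds named here, no measured step points in either direction, so the expectation rests only on the fact that all measured values sit at the limit.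

Compound 4 is expected to give about 40000 nM, between 20000 nM and 80000 nM. The step expected here, a number no higher from compound 2 to compound 4 (the limit leaves the size open), is none beyond the scatter.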

Compound 4, half-maximal cytotoxic concentration: > 40000 nM
Compound 4 was reported as a limit; the forecaster's own chance of this, stated with the estimate: 85%; the middle value lies on the limit itself.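

The step from compound 2 to compound 4, methoxycarbonyl in place of methylsulfonyl on an amine nitrogen in a ring, cannot be read, since neither compound has a number of its own, only a limit: the limit of > 40000 nM in this assay, at which 4 of the 4 values shown sit.

The compounds shown leave open how much of any of them is tolerated in this assay, and whether any of these changes alters that amount.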